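A few compounds are considered here, and "the series" means these few. Any claim that something is new, unique, unknown or untested is made for them only; others in the source may bear on it.

Of the compounds shown here, three sharing one core have been measured in a functional assay on CHO cells for positive allosteric modulation of muscarinic acetylcholine receptor M5 (Homo sapiens), read by FLIPR and calcium flux, with a stated time of 1 h; a lower number here means that less compound is needed, a higher number that more compound is needed for the effect. Compound 1 `O=C1C(=O)N(Cc2ccc(-c3cccnc3)cc2)c2ccc(OC(F)(F)F)cc21` gives 1600 nM. Compound 2 `O=C1C(=O)N(Cc2ccc(Oc3ccccn3)cc2)c2ccc(OC(F)(F)F)cc21` gives 3200 nM. Compound 3 `O=C1C(=O)N(Cc2ccc(Oc3nccs3)cc2)c2ccc(OC(F)(F)F)cc21` gives 2800 nM. Compound 3 therefore sits close to compound 2, and its distance from compound 1 also stays within the usual scatter, so none of the three can be called apart from the others.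

Compound 4 `O=C1C(=O)N(Cc2ccc(Oc3cccc(F)n3)cc2)c2ccc(OC(F)(F)F)cc21` is not yet measured. It differs from compound 3 by 6-fluoropyridin-2-yl in place of 1,3-thiazol-2-yl on an oxygen on an aromatic ring.

The step that bears most directly on this change is a 1.1-fold lower number from compound 2 to compound 3 (0.06 log units; within the scatter), where a different ring was swapped on the same oxygen without any clear effect. The steps of a 2.0-fold higher number from compound 1 to compound 2 (0.30 log units; within the scatter) and a 1.8-fold higher number from compound 1 to compound 3 (0.24 log units; within the scatter) show that moving from a directly attached ring to an oxygen-linked ring also stayed within the scatter. Swapping rings on this oxygen has so far changed nothing beyond the scatter, so no step beyond the scatter is expected in this assay either. Compound 4 is therefore estimated at 2800 nM, with a likely range from 1200 nM to 6500 nM, meaning an expected step of no change at the digits printed from compound 3 to compound 4 (within the scatter).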

Compound 4, half-maximal effective concentration: 1500 nM
Compound 4: the middle estimate sits 1.9-fold (0.27 log units) above what was measured; low and high end bracket the measured number.
By their numbers in this assay, from the lowest: compounds 4, 1, 3 and 2 (each within the scatter of the next, the first and the last beyond it).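

In this assay fluoro in place of hydrogen on an aromatic carbon of the oxygen-linked ring brings a 2.1-fold lower number from compound 2 to compound 4 (0.33 log units; beyond the scatter) and this is the first step among these compounds to lie beyond the scatter, though only modestly. Replacing 1,3-thiazol-2-yl with 6-fluoropyridin-2-yl on the oxygen brings a 1.9-fold lower number from compound 3 to compound 4 (0.27 log units; within the scatter) and replacing pyridin-3-yl with (6-fluoropyridin-2-yl)oxy brings a 1.1-fold lower number from compound 1 to compound 4 (0.03 log units; within the scatter) and both stay within the scatter, so compound 4 cannot be told apart from compound 3 or compound 1.

Still open, on these data alone, is whether chloro, methyl or methoxy in place of the fluoro would bring a similar step, and whether an amine or a longer chain in place of the whole ring would keep the effect. As far as these compounds go, it is also open whether a linker other than the oxygen, such as a methylene group, would change the picture. No measurement shown here offers a reason for the fluoro step.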